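A few compounds are considered here, and "the series" means these few. Any claim that something is new, unique, unknown or untested is made for them only; others in the source may bear on it.

Measured so far:
- compound 1, `COc1cc(C(=O)c2sc(-c3ccncc3)cc2N)cc(OC)c1OC`: 1810 nM in a functional assay on L1210 cells (Mus musculus) for antiproliferative activity; on this read-out lower numbers stand for stronger inhibition and higher numbers for weaker inhibition
- compound 2, `COc1cc(C(=O)c2sc(-c3cc(OC)c(OC)c(OC)c3)cc2N)cc(OC)c1OC`: 2300 nM in this assay

Compound 1 gives the lower of the two numbers in this assay, but its gap to compound 2 lies within the usual scatter, so the two values tell nothing about order; the pyridin-4-yl and trimethoxyphenyl variants of the shared core sit at the same level as far as these data show.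

Compound 3, `CCOc1ccc(-c2cc(N)c(C(=O)c3cc(OC)c(OC)c(OC)c3)s2)cc1`, has not yet been measured. Compared with compound 1 it carries the following change: 4-ethoxyphenyl in place of pyridin-4-yl on an aromatic carbon

Within the data shown here, no step between two measured compounds exists that would calibrate this exchange, so the expectation rests on the level set by compound 1 and compound 2 alone. Both measured aryl groups give numbers of the same size, and there is no basis here for expecting a swing beyond the scatter in either direction. The step from compound 1 to compound 3 is estimated at a 1.4-fold lower number from compound 1 to compound 3 (0.14 log units; within the scatter), essentially flat. Compound 3 is expected to come out near 1300 nM, with a plausible range from 300 nM to 5500 nM.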

Compound 3, half-maximal inhibitory concentration: 590 nM
Estimate against measurement, compound 3: 2.2-fold (0.34 log units) above; measured number inside the range.
By their numbers in this assay, from the lowest: compound 3; then compounds 1 and 2 (each within the scatter of the next).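

At the aromatic carbon next to the ring sulfur, 4-ethoxyphenyl in place of pyridin-4-yl gives a 3.1-fold lower number from compound 1 to compound 3 (0.49 log units; beyond the scatter) in this assay and so shows that the read-out responds to the aryl group at this position, which the earlier pair could not show: compound 1 at 1810 nM and compound 2 at 2300 nM lie within the scatter of each other. The exchange alters two things in one step, replacing a six-membered aromatic ring with 1 hetero atom by one of carbon only and adding the ethoxy group, so the step cannot be divided between the ring and the ethoxy group. The data at hand offer no independent measurement that accounts for the step.

Open, going by these compounds, is whether phenyl without a substituent, 4-methoxyphenyl or a longer chain such as 4-butoxyphenyl would hold, extend or lose this step, and this would separate the contribution of the ring from that of the ethoxy group. Also open, on these data alone, is whether a 4-aminophenyl or 4-carboxyphenyl group at the same carbon would sit with compound 3 or nearer compound 1.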